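Swapping a Pyridine for a Thiophene in an Orexin Agonist

A few compounds are considered here, and "the series" means these few. Any claim that something is new, unique, unknown or untested is made for them only; others in the source may bear on it.

Measured compounds:
- compound 1 `COc1ccc(-c2cccc(C(=O)N(C)C)c2)cc1S(=O)(=O)Nc1cccc(NCC(C)NC(=O)c2cccc(C)c2)c1`: 666 nM
- compound 2 `COc1ccc(-c2cncc(C(=O)N(C)C)c2)cc1S(=O)(=O)Nc1cccc(NCCNC(=O)c2cccc(C)c2)c1`: 7530 nM

Both compounds share a core in which a sulfonamide links a methoxy-bearing aromatic ring to a second aromatic ring that carries an amine-linked chain ending in a methylbenzamide. They were tested in a functional assay on CHO-RD-HGA16 cells for agonist activity at Orexin/Hypocretin receptor type 1 (Homo sapiens), read by fluorescence and calcium flux, with a stated time of 30 min; a higher number here means that more compound is needed for the effect, a lower number that less compound is needed. In this assay compound 1 gives 666 nM, while compound 2 gives 7530 nM, the highest of the two numbers and well beyond the usual scatter from compound 1. The two compounds differ in more than one place, so their gap cannot be tied to a single change.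

Compound 3 `COc1ccc(-c2csc(C(=O)N(C)C)c2)cc1S(=O)(=O)Nc1cccc(NCCNC(=O)c2cccc(C)c2)c1` is not yet measured. It differs from compound 2 in one place: 5-(dimethylcarbamoyl)thiophen-3-yl in place of 5-(dimethylcarbamoyl)pyridin-3-yl on an aromatic carbon. Among the measured compounds shown here, no measured pair shows this particular exchange, so the direction of the step is uncertain. Compound 1, with a carbon-only ring at this position, gives the lower number, and a five-membered sulfur ring is a move away from the pyridine. On that basis compound 3 is expected to come in somewhat lower than compound 2, a step of about a 2.5-fold lower number from compound 2 to compound 3 (0.40 log units; beyond the scatter), though a result within the scatter would not be surprising. The estimate for compound 3 is 3000 nM, with a range from 800 nM to 12000 nM.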

Compound 3, half-maximal effective concentration: 1330 nM
For compound 3 the middle estimate is 2.3-fold (0.35 log units) above the measured one; measured number inside the range.
By their numbers in this assay, from the lowest: compounds 1 and 3 (each within the scatter of the next); then compound 2.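

Among the compounds shown here, compound 3 gives the first reading of a change at this one position. In this assay, putting 5-(dimethylcarbamoyl)thiophen-3-yl in place of 5-(dimethylcarbamoyl)pyridin-3-yl, on the aromatic carbon para to the methoxy group, gives a 5.7-fold lower number from compound 2 to compound 3 (0.75 log units; beyond the scatter) in a step that lies beyond the usual scatter. The position therefore responds to the identity of the ring even though the dimethylcarbamoyl group stays on it, and a five-membered aromatic ring with sulfur as its hetero atom is accepted here without any rise in the number. The leaving and entering groups have the same counts of hydrogen-bond donors and acceptors, so those counts alone do not follow this step.

The compounds shown leave open whether a furan ring, or a carboxylic acid or primary amide in place of the dimethylcarbamoyl group on the thiophene, would move the number further, and compound 1 differs from compound 3 in more than one place, so its ring and its chain cannot be weighed separately. No measurement here gives a reason for the step from the pyridine to the thiophene.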